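Trimming the aryl group to methyl on the shared core

A few compounds are considered here, and "the series" means these few. Any claim that something is new, unique, unknown or untested is made for them only; others in the source may bear on it.

Measured compounds:
compound 1 `CC(C)(C)n1ncc(OCc2nnc(-c3ccc(Br)cc3)o2)c(Cl)c1=O`: 21400 nM
compound 2 `CC(C)(C)n1ncc(OCc2nnc(-c3cc(F)c(Cl)cc3Cl)s2)c(Cl)c1=O`: 67100 nM
compound 3 `Cc1cc(C)cc(-c2nnc(COc3cnn(C(C)(C)C)c(=O)c3Cl)s2)c1`: a limit only, > 299000 nM

In a functional assay on the whole organism for inhibition, with Mythimna separata as the target, with a stated time of 5 days (on this read-out lower numbers stand for an effect already at smaller amounts and higher numbers for an effect only at larger amounts of compound), compound 1 gives the lowest of the two numbers shown, with compound 2 beyond the scatter above it. Compound 3 reaches only (the limit of > 299000 nM in this assay, at which 1 of the 3 values shown sits). For the measured compounds named here, the single measured step, an at least 4.4-fold higher number from compound 2 to compound 3 (0.64 log units; beyond the scatter), shows that changing the aryl group on the five-membered ring can raise the number substantially. Compound 4 `Cc1nnc(COc2cnn(C(C)(C)C)c(=O)c2Cl)o1` differs from compound 1 by methyl in place of 4-bromophenyl on an aromatic carbon. Going by the values given here, no measured step removes the aryl ring altogether, so the guidance is indirect. Compound 4 is nonetheless expected to give a higher number, a step of a 7.0-fold higher number from compound 1 to compound 4 (0.85 log units; beyond the scatter). The estimate for compound 4 is 150000 nM, within a range from 40000 nM to 450000 nM.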

Compound 4, half-maximal effective concentration: > 299000 nM
Compound 4: a limit, no number; the forecaster's own chance of this, stated with the estimate: 40%; middle value at least 1.9-fold (0.29 log units) away from the limit.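

Replacing 4-bromophenyl with methyl on this aromatic carbon gives an at least 13-fold higher number from compound 1 to compound 4 (1.14 log units; beyond the scatter) in this assay. The earlier step only exchanged one aryl group for another, whereas this one shows that the low number of compound 1 is lost when the six-membered aromatic ring of carbon leaves this place. Compound 4 gives only a limit, not a number: the limit of > 299000 nM in this assay, at which 2 of the 4 values shown sit.

The compounds shown leave open whether unsubstituted phenyl would keep the number of compound 1 without the bromine. They also leave open whether a longer chain such as butyl or an amine at this carbon would bring back a measurable number.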